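Ring-Closed Amine Variant Tested for Sphingosine-1-Phosphate Transporter Inhibition

The compounds below may be only part of what the source reports. "The series", "measured", "known", "first", "only" and "open" are said of these compounds alone.

Measured compounds:
compound 1 `CCCCCCCCCCc1ccc(-c2noc(CCCN)n2)cc1`: 67%
compound 2 `CCCCCCCCCCc1ccc(-c2noc(CCCCN)n2)cc1`: 55%
compound 3 `CCCCCCCCCCc1ccc(-c2noc(CCCNC)n2)cc1`: 45%

Three compounds share one core and differ only in the amine-bearing chain attached to it. In an assay on HeLa cells for inhibition of sphingosine-1-phosphate transporter SPNS2 (Mus musculus), read by LC-MS, tested at 2 uM (on this read-out lower numbers stand for less inhibition and higher numbers for more inhibition at the one concentration tested (going by the name of the read-out)), compound 1 gives 67%, the highest of the three numbers. Compound 3 stands lowest: its nearest neighbour is compound 2, whose number is higher but within the scatter, and its furthest is compound 1, beyond the scatter.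

The measured steps are modest. a number 12 percentage points lower from compound 1 to compound 2 (beyond the scatter) follows aminomethyl in place of amino on a saturated chain carbon, three bonds along the chain from an aromatic carbon. a number 22 percentage points lower from compound 1 to compound 3 (beyond the scatter) follows methyl in place of hydrogen on an amine nitrogen. a number 10 percentage points lower from compound 2 to compound 3 (within the scatter) lies within the scatter.

Compound 4 `CCCCCCCCCCc1ccc(-c2noc([C@@H]3CCNC3)n2)cc1` has not yet been measured. Its difference from compound 3 is pyrrolidin-3-yl in place of 3-(methylamino)propyl on an aromatic carbon. The amine nitrogen keeps one hydrogen-bond donor but now sits in a ring, so the methyl on nitrogen that accompanied a number 22 percentage points lower from compound 1 to compound 3 (beyond the scatter) is gone. Because of that step, a small rise is expected, though neither measured step reproduces the ring closure itself. The expected step is a number 10 percentage points higher from compound 3 to compound 4 (within the scatter). Compound 4 is therefore estimated at 55%, with a range from 35% to 75%.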

Compound 4, a percentage reported as inhibition, at one concentration (the size of the read-out at that concentration, not a potency): 62%
Compound 4: middle estimate off by 7 percentage points, on the low side; measured number inside the range.
By their numbers in this assay, from the lowest: compounds 3, 2, 4 and 1 (each within the scatter of the next, the first and the last beyond it).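

In this assay, the pyrrolidin-3-yl group shows that the amine on this aromatic carbon need not sit on an open chain: a number 17 percentage points higher from compound 3 to compound 4 (beyond the scatter) accompanies a swap that leaves the counts of heavy atoms, hydrogen-bond donors and hydrogen-bond acceptors unchanged but adds a five-membered non-aromatic ring and a defined stereocentre. Compound 4 has a secondary amine, as compound 3 does, so a secondary amine alone does not go with the lowest number in this set, and the ring stays within the scatter of both primary amine chains, with a number 7 percentage points higher from compound 2 to compound 4 (within the scatter) and with a number 5 percentage points lower from compound 1 to compound 4 (within the scatter). Nothing available explains why closing the ring accompanies this step.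

The compounds shown leave open how the mirror-image pyrrolidin-3-yl group would compare, and whether the ring size matters, as an azetidin-3-yl or piperidin-4-yl group at this position would show. They also leave open whether an N-methylpyrrolidin-3-yl group would repeat the step seen on the open chain when methyl was placed on the amine nitrogen, and whether these differences at one concentration would hold as differences in potency.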